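The source may report more compounds than this note shows. Statements on the series, on what has been measured and on what is new or still open speak of the compounds shown alone.

Measured in a functional assay on HeLa cells (Homo sapiens) for cytotoxicity, read by MTT assay, with a stated time of 72 h; a lower number here means a stronger inhibitor, a higher number a weaker inhibitor:

compound 1 `O=C(/C=C/c1ccc([N+](=O)[O-])cc1)Nc1cc2c(Nc3ccc(F)c(Cl)c3)ncnc2cc1O[C@H]1CCOC1`: 27400 nM
compound 2 `COc1cc(/C=C/C(=O)Nc2cc3c(Nc4ccc(F)c(Cl)c4)ncnc3cc2O[C@H]2CCOC2)cc(OC)c1`: 34300 nM
compound 3 `COc1ccc(/C=C/C(=O)Nc2cc3c(Nc4ccc(F)c(Cl)c4)ncnc3cc2O[C@H]2CCOC2)c(OC)c1`: 26500 nM

Compound 1 holds the second highest of the three numbers; its nearest neighbour is compound 3 and its furthest compound 2, and both gaps lie within the scatter. Compound 4 `COc1ccc(/C=C/C(=O)Nc2cc3c(Nc4ccc(F)c(Cl)c4)ncnc3cc2O[C@H]2CCOC2)cc1` differs from compound 1 by methoxy in place of nitro on an aromatic carbon. Going by the values given here, the steps that bear on this exchange are a 1.3-fold higher number from compound 1 to compound 2 (0.10 log units; within the scatter) and a 1.0-fold lower number from compound 1 to compound 3 (0.01 log units; within the scatter), which swap the same 4-nitrophenyl for substituted phenyls and move the number only within the scatter; a 1.3-fold lower number from compound 2 to compound 3 (0.11 log units; within the scatter) is likewise flat. No shift beyond the scatter is therefore expected in this assay. For compound 4 the expected value is 27000 nM (range 13000 nM to 56000 nM), an expected step of a 1.0-fold lower number from compound 1 to compound 4 (0.01 log units; within the scatter).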

Compound 4, half-maximal inhibitory concentration: 34600 nM
For compound 4 the middle estimate is 1.3-fold (0.11 log units) below the measured one; the range from low to high includes it.
By their numbers in this assay, from the lowest: compounds 3, 1, 2 and 4 (each within the scatter of the next).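

In this assay, the direct exchange of nitro for methoxy on the aromatic carbon para to a large group stays within the scatter (a 1.3-fold higher number from compound 1 to compound 4 (0.10 log units; within the scatter)). The 4-methoxyphenyl group also shows no separation from the dimethoxyphenyl groups, either with hydrogen in place of methoxy (a 1.3-fold higher number from compound 3 to compound 4 (0.12 log units; within the scatter)) or with 4-methoxyphenyl in place of 3,5-dimethoxyphenyl (a 1.0-fold higher number from compound 2 to compound 4 (0.00 log units; within the scatter)). No available evidence bears on this flat result.

Still open, on these data alone, is whether an amine or a carboxylic acid at this position would move the number beyond the scatter.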